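This account rests on a few compounds, and the source may have more. Where it says the series, first, only, none or still open, it means among the compounds named here.

In an ADME assay on J774.A1 cells (Mus musculus) for cytotoxicity, read by MTT assay, with a stated time of 48 h (a lower number here means that less compound is tolerated, a higher number that more compound is tolerated), compound 1 (`COC(=O)c1c([N+](=O)[O-])noc1-c1ccc(Cl)cc1Cl`) gives 19700 nM. Compound 2 (`O=C(NCc1ccccc1)c1c([N+](=O)[O-])noc1-c1ccc(Cl)cc1Cl`) has no single number to set beside it, its entry reading "not determined" (no result reported). Compound 3 (`O=C(NCc1ccc(F)cc1)c1c([N+](=O)[O-])noc1-c1ccc(Cl)cc1Cl`) carries one change relative to compound 2: fluoro in place of hydrogen on an aromatic carbon, a fluoro in place of hydrogen on an aromatic carbon, which turns benzyl into 4-fluorobenzyl. No measured step sizes this change, so no shift beyond the usual scatter is expected in this assay, and no direction is favoured. Among the compounds with values here, the only number available as an anchor is that of compound 1 at 19700 nM. For compound 3, the expected value is estimated at 20000 nM, within a range of 6000 nM to 60000 nM.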

Compound 3, half-maximal cytotoxic concentration: 86400 nM
Compound 3: the middle estimate sits 4.3-fold (0.64 log units) below what was measured; measured number outside the range, above it.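

Replacing methoxy on the carbonyl carbon with (4-fluorobenzyl)amino gives a 4.4-fold higher number from compound 1 to compound 3 (0.64 log units; beyond the scatter) in this assay and so shows that this position can shift the read-out beyond the scatter, towards more compound being tolerated. The effect of fluoro in place of hydrogen alone cannot be read, as compound 2 has no number to set against compound 3. No measurement shown accounts for the step. The compounds shown leave open how a carboxylic acid on that carbonyl carbon, or a longer chain in place of 4-fluorobenzyl, would stand in this assay.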